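A few compounds are considered here, and "the series" means these few. Any claim that something is new, unique, unknown or untested is made for them only; others in the source may bear on it.

Measured so far:
- compound 1, `O=C(/C=C/c1ccc(N2CCCCC2)cc1)c1cccs1`, with 65500 nM in an ADME assay on Vero cells (Chlorocebus sabaeus) for cytotoxicity, with a stated time of 5 days; a lower number here means a stronger inhibitor, a higher number a weaker inhibitor
- compound 2, `Cc1ccsc1C(=O)/C=C/c1ccc(N2CCCCC2)cc1`, with 63900 nM in this assay

Compound 2 stands at the lowest of the two numbers in this assay, but its nearest neighbour is compound 1, and the step of a 1.0-fold lower number from compound 1 to compound 2 (0.01 log units; within the scatter) is within the scatter, so the two compounds cannot be told apart by these numbers. That step replaced a hydrogen with a methyl on an aromatic carbon.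

Compound 3, `O=C(/C=C/c1ccc(N2CCCCC2)cc1)c1cc(Cl)sc1Cl`, is not yet measured. Compared with compound 2 the change is 2,5-dichlorothiophen-3-yl in place of 3-methylthiophen-2-yl on a carbonyl carbon. For the measured compounds named here, no measured step touches the thiophene ring in this way; the only step known, from compound 1 to compound 2, was a small addition to that ring and left the number unchanged within the scatter. There is therefore no basis for expecting a step in this assay beyond the scatter in either direction, and the estimate is wide. Compound 3 is expected to give about 60000 nM, with a range from 20000 nM to 150000 nM, which is the step of a 1.1-fold lower number from compound 2 to compound 3 (0.03 log units; within the scatter) from compound 2.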

Compound 3, half-maximal inhibitory concentration: 24900 nM
Compound 3: the middle estimate sits 2.4-fold (0.38 log units) above what was measured; the range from low to high includes it.
By their numbers in this assay, from the lowest: compound 3; then compounds 2 and 1 (each within the scatter of the next).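

Changing the ring group on the carbonyl carbon does move the number in this assay, which the earlier methyl step did not: 2,5-dichlorothiophen-3-yl in place of 3-methylthiophen-2-yl gives a 2.6-fold lower number from compound 2 to compound 3 (0.41 log units; beyond the scatter), and in place of thiophen-2-yl it gives a 2.6-fold lower number from compound 1 to compound 3 (0.42 log units; beyond the scatter). Both steps are modest but beyond the scatter, and they point towards a stronger inhibitor; as compound 1 and compound 2 cannot be told apart, they amount to one observation reached from two starting points rather than two independent findings. Nothing available here accounts for the shift.

The compounds shown leave open which part of the swap carries the step, the chlorines or the change from a thiophen-2-yl to a thiophen-3-yl attachment, since these arrive together in compound 3. They also leave open how the number would respond to other groups on this ring, such as a bromine, a methoxy group or an amine.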